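Cyclopropyl for trifluoromethyl on the imidazole of compound 2

The source may report more compounds than this note shows. Statements on the series, on what has been measured and on what is new or still open speak of the compounds shown alone.

Compound 1 `CNC(=O)[C@@H](c1ccccc1)N1CCn2c(CC3CC3)nc(Cl)c2[C@@H]1CCc1ccc(C(F)(F)F)cc1` gives 1430 nM in a functional assay on CHO cells for antagonist activity at Orexin/Hypocretin receptor type 1 (Homo sapiens), read by FLIPR and calcium flux; on this read-out higher numbers stand for weaker inhibition and lower numbers for stronger inhibition. Compound 2 `CCc1nc(C(F)(F)F)c2n1CCN([C@@H](C(=O)NC)c1ccccc1)[C@H]2CCc1ccc(C(F)(F)F)cc1` gives 1070 nM. Compound 3 `CCc1nc(C(C)C)c2n1CCN([C@@H](C(=O)NC)c1ccccc1)C2CCc1ccc(C(F)(F)F)cc1` gives 10000 nM.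

Compound 2 shows the lowest number of the three, but the number of compound 1 lies within the scatter of it, so the two cannot be ordered; only compound 3 is clearly weaker. Compound 4 `CCc1nc(C2CC2)c2n1CCN([C@@H](C(=O)NC)c1ccccc1)[C@H]2CCc1ccc(C(F)(F)F)cc1` has not been measured. It differs from compound 2 in one place: cyclopropyl in place of trifluoromethyl on an aromatic carbon. Among the compounds with values here, no measured pair shows this exact change. Compound 3, which carries an isopropyl group at that aromatic carbon, gives 10000 nM, far weaker than compound 2. The cyclopropyl group is expected to fall between these cases, so compound 4 is expected to give 3000 nM (range 900 nM to 10000 nM). The expected step is a 2.8-fold higher number from compound 2 to compound 4 (0.45 log units; beyond the scatter), a modest loss that may reach beyond the scatter.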

Compound 4, half-maximal inhibitory concentration: 4170 nM
Estimate against measurement, compound 4: 1.4-fold (0.14 log units) below, within the range that was stated.
By their numbers in this assay, from the lowest: compounds 2 and 1 (each within the scatter of the next); then compound 4; then compound 3.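

Cyclopropyl in place of trifluoromethyl on this aromatic carbon gives a 3.9-fold higher number from compound 2 to compound 4 (0.59 log units; beyond the scatter) (in this assay), the first change in one place alone that can be read at this position. It shows that the number depends on the group held here, and that a carbon-only ring does not keep the number of compound 2. Nothing measured here accounts for the step.

On these data alone, whether a methyl group, a nitrile or an amine at this aromatic carbon would keep the number of compound 2 stays open. So does whether the step would be the same with a group other than ethyl on the neighbouring ring atom that bears it.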